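From benzyl to tert-butyl on the shared core

A few compounds are considered here, and "the series" means these few. Any claim that something is new, unique, unknown or untested is made for them only; others in the source may bear on it.

In a functional assay on THP-1 cells (Homo sapiens) for inhibition, read by ELISA, with stated times of 2 h and 48 h (a lower number here means a stronger inhibitor, a higher number a weaker inhibitor), compound 1 (`[O-]/[N+](=C\c1cn(-c2ccccc2)nn1)c1ccccc1`) gives 8800 nM and compound 2 (`[O-]/[N+](=C\c1cn(-c2ccccc2)nn1)Cc1ccccc1`) gives 8000 nM. Among the compounds with values here, these two values lie within the scatter of each other, so compound 2 stands level with the only other number available. The next structure is compound 3 (`CC(C)(C)/[N+]([O-])=C/c1cn(-c2ccccc2)nn1`), which differs from compound 2 as follows: tert-butyl in place of benzyl on a double-bonded nitrogen. This puts tert-butyl in place of benzyl on a double-bonded nitrogen. Within the data shown here, only one measured step bears on this place: a 1.1-fold lower number from compound 1 to compound 2 (0.04 log units; within the scatter), with benzyl in place of phenyl and a result within the scatter. Among the measured compounds shown here, both groups in that step carry a ring, whereas tert-butyl has none, and no compound without a ring at this place has been measured. The evidence is therefore thin, and the range must stay wide. In this assay, no shift beyond the scatter is expected, and the estimated change is a 1.1-fold lower number from compound 2 to compound 3 (0.03 log units; within the scatter). For compound 3 the expected value is 7500 nM, with an estimated range of 2500 nM to 20000 nM.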

Compound 3, half-maximal inhibitory concentration: > 20000 nM
Compound 3 gave a limit, no number (the forecaster's own chance of this, stated with the estimate: 15%); at least 2.6-fold (0.42 log units) between middle value and limit.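

In this assay, the place on the double-bonded nitrogen now proves sensitive to the group it carries: exchanging phenyl for benzyl left the number within the scatter, whereas tert-butyl gives an at least 2.5-fold higher number from compound 2 to compound 3 (0.39 log units; beyond the scatter) and an at least 2.2-fold higher number from compound 1 to compound 3 (0.35 log units; beyond the scatter). Compound 3 stands at a limit of the assay, not at a number: the limit of > 20000 nM in this assay, at which 1 of the 3 values shown sits. Among these three compounds, the two with a six-membered aromatic ring of carbon only in the group at this place read alike, the one with no ring there reads as the weaker inhibitor, and the full size of both steps stays open on the upper side.

As far as these compounds go, whether the step follows from losing the ring or from tert-butyl itself remains open; a cyclohexyl group or a straight butyl chain at this place would separate the two. Also open, from the compounds shown here alone, is whether an amine or a carboxylic acid on the ring of the benzyl group would move the number away from the level of compound 2.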